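This account rests on a few compounds, and the source may have more. Where it says the series, first, only, none or still open, it means among the compounds named here.

Three compounds share a core and carry different groups on the outer aromatic ring; each was measured in a functional assay on CHO cells for positive allosteric modulation of metabotropic glutamate receptor 2 (Homo sapiens), read by scintillation counting and GTPgammaS binding, with a stated time of 30 min; on this read-out lower numbers stand for an effect already at smaller amounts and higher numbers for an effect only at larger amounts of compound:

Compound 1 `CC(C)CCn1ccc(-c2ccccc2)c(C#N)c1=O` gives 8510 nM in this assay.
Compound 2 `CC(C)CCn1ccc(-c2ccc(OCC3CC3)cc2)c(C#N)c1=O` gives 290 nM in this assay.
Compound 3 `CC(C)CCn1ccc(-c2ccc(Oc3ccncc3)cc2)c(C#N)c1=O` gives 550 nM in this assay.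

Compound 3 lies far from compound 1 and close to compound 2, the two of them apart by less than the usual scatter. Putting a group on the outer ring moved the number strongly: a 29-fold lower number from compound 1 to compound 2 (1.47 log units; beyond the scatter) and a 15-fold lower number from compound 1 to compound 3 (1.19 log units; beyond the scatter). Exchanging one such group for another did little: a 1.9-fold higher number from compound 2 to compound 3 (0.28 log units; within the scatter).

Compound 4 `Cc1cc(Oc2ccc(-c3ccn(CCC(C)C)c(=O)c3C#N)cc2)ccn1` is compound 3 with methyl in place of hydrogen on an aromatic carbon. Going by the values given here, no measured step adds a methyl to the pyridin-4-yl group, so there is no direct precedent. The measured steps show that the group on the ether oxygen mattered greatly, while the exact choice of that group hardly changed the number between compound 2 and compound 3. A single added methyl is therefore expected to give a step within the scatter, in no clear direction: a 1.2-fold lower number from compound 3 to compound 4 (0.09 log units; within the scatter). Compound 4 is expected at 450 nM, with a range from 150 nM to 1300 nM.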

Compound 4, half-maximal effective concentration: 447 nM
Compound 4: the middle estimate sits 1.0-fold (0.00 log units) above what was measured; the range from low to high includes it.
By their numbers in this assay, from the lowest: compounds 2, 4 and 3 (each within the scatter of the next); then compound 1.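

Adding a methyl next to the ring nitrogen, which turns pyridin-4-yl into 2-methylpyridin-4-yl, gives in this assay a 1.2-fold lower number from compound 3 to compound 4 (0.09 log units; within the scatter) and so leaves no readable change at this position. The new group also stays level with cyclopropylmethyl, with a 1.5-fold higher number from compound 2 to compound 4 (0.19 log units; within the scatter) on that exchange, and it keeps the large distance from the unsubstituted outer ring of the core, with a 19-fold lower number from compound 1 to compound 4 (1.28 log units; beyond the scatter) on that comparison. The data offer no explanation for how little this methyl alters the number.

As far as these compounds go, whether this position would accept something larger than methyl, such as a tert-butyl group, or something different in kind, such as an amine or a carboxylic acid, remains open. A single methyl at a single position also cannot show how the rest of the pyridine ring responds to substitution.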